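A few compounds are considered here, and "the series" means these few. Any claim that something is new, unique, unknown or untested is made for them only; others in the source may bear on it.

The opening compound, compound 1 `CC(C)[C@H](NC(=O)COc1cccc2ccccc12)C(=O)N[C@@H](CC(=O)O)C(=O)COc1ccccn1`, carries a pyridin-2-yl ether on the saturated carbon of the ketone. In a functional assay on Jurkat cells (Homo sapiens) for inhibition (a higher number here means a weaker inhibitor, a lower number a stronger inhibitor), compound 1 gives > 200000 nM, which is a limit of the assay and not a number. Compound 2 `CC(C)[C@H](NC(=O)COc1cccc2ccccc12)C(=O)N[C@@H](CC(=O)O)C(=O)COc1ccncn1` differs from it by pyrimidin-4-yl in place of pyridin-2-yl on an oxygen on a saturated carbon, a step read as a step that the two limits leave unreadable from compound 1 to compound 2. In this assay compound 2 gives > 200000 nM, again a limit rather than a number. Compound 2 therefore stands at the limit of > 200000 nM in this assay, at which 2 of the 2 values shown sit, and nothing measured in this series places it any more precisely.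

Compound 3 `Cc1cc(C)nc(SCC(=O)[C@H](CC(=O)O)NC(=O)[C@@H](NC(=O)COc2cccc3ccccc23)C(C)C)n1` is the next compound to be measured. It differs from compound 2 by (4,6-dimethylpyrimidin-2-yl)sulfanyl in place of (pyrimidin-4-yl)oxy on a saturated chain carbon bound to a carbonyl carbon. Among the compounds with values here, no measured step shares this change: the only step in hand swaps one aromatic ring for another on an oxygen, and it is itself unreadable between two limits. The expectation for compound 3 in this assay thus rests on weak ground, and the expected step from compound 2 to compound 3 is an at least 2.0-fold lower number from compound 2 to compound 3 (0.30 log units; that floor lies within the scatter), with a considerable chance that the assay again reports only a limit. Compound 3 is estimated at 100000 nM, within a range from 10000 nM to 400000 nM.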

Compound 3, half-maximal inhibitory concentration: > 200000 nM
Compound 3 was reported as a limit (the forecaster's own chance of this, stated with the estimate: 55%); middle value at least 2.0-fold (0.30 log units) away from the limit.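

No step can be read among compound 1, compound 2 and compound 3, as all three values are limits of the assay and not numbers: the limit of > 200000 nM in this assay, at which 3 of the 3 values shown sit.

The compounds shown leave open whether exchanging the group on the saturated chain carbon bound to a carbonyl carbon changes inhibition in this assay at all, and in which direction.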